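A few compounds are considered here, and "the series" means these few. Any claim that something is new, unique, unknown or untested is made for them only; others in the source may bear on it.

Going by the values given here, in a functional assay on CAKI-1 cells (Homo sapiens) for cytotoxicity, read by sulforhodamine B assay (on this read-out higher numbers stand for an effect only at larger amounts of compound and lower numbers for an effect already at smaller amounts), two compounds have numbers so far. Compound 1 `COc1cccc(C2CC(=O)c3ccccc3N2)c1`, drawn without a configuration at its stereocentre, gives 0.32 ug/mL. Compound 2 `COc1cccc([C@@H]2CC(=O)c3ccccc3N2)c1`, drawn S at that carbon, gives 0.15 ug/mL, the lower of the two numbers. The measured change is a 2.1-fold lower number from compound 1 to compound 2 (0.33 log units; beyond the scatter), and all that separates the pair is the fact that one of compounds 1 and 2 is drawn with a defined configuration and the other without, at the place where they differ. Compound 3 `COc1cccc([C@H]2CC(=O)c3ccccc3N2)c1` takes the opposite configuration: the two compounds have the same atoms and bonds and differ only in configuration as drawn: 1 of 1 stereo elements differ; a stereocentre at a saturated ring carbon is drawn S in compound 2 and R in compound 3.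

Among the compounds with values here, only that one modest step bears on this change, so the forecast rests on thin evidence. If compound 1 is an equal mixture of the S and R forms, which its drawing does not establish, then a 2.1-fold lower number from compound 1 to compound 2 (0.33 log units; beyond the scatter) is about what would be seen if the S form carried nearly all of the effect and the R form little. On that reading, a higher number is expected in this assay, beyond the scatter, although its size is poorly bounded. The expected change is a 10-fold higher number from compound 2 to compound 3 (1.00 log units; beyond the scatter). For compound 3 the estimated value is 1.5 ug/mL, with an expected range from 0.35 ug/mL to 10 ug/mL.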

Compound 3, concentration for half-maximal effect: 3.8 ug/mL
Compound 3: the middle estimate sits 2.5-fold (0.40 log units) below what was measured, within the range that was stated.
By their numbers in this assay, from the lowest: compound 2; then compound 1; then compound 3.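

The opposite configuration shows that this stereocentre at a saturated ring carbon carries far more weight in this assay than the first comparison could reveal: going from S to R gives a 25-fold higher number from compound 2 to compound 3 (1.40 log units; beyond the scatter), a large step set against the modest 2.1-fold lower number from compound 1 to compound 2 (0.33 log units; beyond the scatter). The compound drawn without a configuration is also clearly separated from the R form, with a 12-fold higher number from compound 1 to compound 3 (1.07 log units; beyond the scatter), so the order of the three numbers is now fixed at both ends, and the drawn S form gives the lowest number of the three. With atoms and bonds shared, the whole of the large gap between the two defined forms can be assigned to the configuration at this one carbon: the fact that compounds 2 and 3 differ only in the configuration as drawn.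

The drawing of compound 1 still does not establish what mixture of the two forms it contains, so its intermediate number cannot be translated into a ratio of S to R. All three compounds also carry the same methoxy group on the same core, which leaves open whether a gap of this size between S and R would persist with a hydroxyl group or a carboxylic acid in its place.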